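The source may hold more compounds than are shown below. What is called first, only, known or untested is meant among the compounds shown, and "the series" means these compounds.

Compound 3 `CCCCCCCCC(=O)O[C@H]1[C@H](O)[C@H](n2ccc(N)nc2=O)O[C@@H]1CO` carries a saturated ester chain on the shared core. In a functional assay on HeLa cells (Homo sapiens) for cytotoxicity, read by cell counting, with a stated time of 48 h (on this read-out higher numbers stand for an effect only at larger amounts of compound and lower numbers for an effect already at smaller amounts), compound 3 gives 0.05 ug/mL. Compound 1 `CCCCCCCC/C=C/CCCCCCCC(=O)O[C@H]1[C@H](O)[C@H](n2ccc(N)nc2=O)O[C@@H]1CO`, whose ester chain is the longest of the three and holds one double bond, gives 0.05 ug/mL in this assay; compound 2 `CCCCCCCCCC(=O)O[C@H]1[C@H](O)[C@H](n2ccc(N)nc2=O)O[C@@H]1CO`, with a saturated chain, gives 0.09 ug/mL. Compound 3 thus stands level with compound 1 at the digits shown, the two together the lowest numbers of the set, and the remaining step within the set reads a 1.8-fold lower number from compound 2 to compound 3 (0.26 log units; within the scatter).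

Compound 4 `CCCCCC(=O)O[C@H]1[C@H](O)[C@H](n2ccc(N)nc2=O)O[C@@H]1CO` is the next cut of the same chain: hydrogen in place of propyl on a saturated chain carbon, five bonds along the chain from a carbonyl carbon. Within the data shown here, every measured step so far only altered the length of the acyl chain: a 1.8-fold higher number from compound 1 to compound 2 (0.26 log units; within the scatter), no change at the digits printed from compound 1 to compound 3 (within the scatter) and a 1.8-fold lower number from compound 2 to compound 3 (0.26 log units; within the scatter). None of these left the scatter, so in this assay no step beyond the scatter is expected from compound 3 to compound 4 either. The chain of compound 4 is, however, shorter than any chain measured, so the range around the expectation is kept wide, open mainly toward a higher number. Compound 4 is therefore expected to give about 0.08 ug/mL in this assay, between 0.03 ug/mL and 0.4 ug/mL, which means an expected step of a 1.6-fold higher number from compound 3 to compound 4 (0.20 log units; within the scatter).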

Compound 4, concentration for half-maximal effect: 0.05 ug/mL
Compound 4: middle estimate off by 1.6-fold (0.20 log units), on the high side; measured number inside the range.
By their numbers in this assay, from the lowest: compounds 1, 3, 4 and 2 (each within the scatter of the next).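

Removing propyl at this place, on a saturated chain carbon, five bonds along the chain from a carbonyl carbon, and putting hydrogen there still gives no step beyond the scatter in this assay: the steps read no change at the digits printed from compound 3 to compound 4 (within the scatter), a 1.8-fold lower number from compound 2 to compound 4 (0.26 log units; within the scatter) and no change at the digits printed from compound 1 to compound 4 (within the scatter). The earlier compounds shown here showed this flat behaviour only among the longer chains, whereas compound 4 extends it to a chain shorter than any of theirs, so that none of the four compounds separates from the others in this assay, and none goes against this reading. Nothing available explains why the numbers hold across these chains.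

All four compounds carry an ester chain on the shared core, so the lower end of the chain series remains undefined: an acetyl ester, or a free hydroxyl in place of the ester, could show whether the numbers hold once the chain is cut further. Also open are an amide in place of the ester and a chain ending in an amine or a carboxylic acid, since every chain shown consists of carbon alone.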